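A few compounds are considered here, and "the series" means these few. Any claim that something is new, unique, unknown or untested is made for them only; others in the source may bear on it.

Compound 1 `CCOC(=O)c1ccc(Nc2ccnc(SCC(=O)c3ccc([N+](=O)[O-])cc3)n2)cc1` is a weak grower-inhibitor in a functional assay on MDA-MB-435 cells (Homo sapiens) for inhibition, read by sulforhodamine B assay, with a stated time of 48 h, tested at 10 uM (a higher number here means more inhibition of growth at the concentration tested, a lower number less inhibition of growth), where compound 1 gives 15%. The only other compound measured alongside it, compound 2 `COc1ccc(C(=O)CSc2nccc(Nc3cccc(C(C)=O)c3)n2)cc1`, gives 15% in this assay, so compound 1 stands level with compound 2 at the digits shown, and the gap between the two lies within the usual scatter of this kind of measurement. Nothing further can be drawn from that pair.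

The step from compound 1 leads to compound 3 `CCOC(=O)c1ccc(Nc2ccnc(SCC(=O)c3ccc(C#N)cc3)n2)cc1`, which carries one change: cyano in place of nitro on an aromatic carbon. Among the compounds with values here, no measured pair in this set shares that change, so there is no direct precedent for its size. Given that compound 1 gives 15% and that the change is confined to a single substituent on the ring, the step of a number 2 percentage points lower from compound 1 to compound 3 (within the scatter) is expected to be small, with no change beyond the scatter as the most likely outcome. Compound 3 is accordingly estimated at 13% in this assay, within a range of 0% to 30%.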

Compound 3, percent growth inhibition at one concentration: 32%
Compound 3: middle estimate off by 19 percentage points, on the low side; the whole stated range lies below it.
By their numbers in this assay, from the lowest: compounds 1 and 2 (each within the scatter of the next); then compound 3.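

In this assay, the exchange of 4-nitrophenyl for 4-cyanophenyl gives a modest step, a number 17 percentage points higher from compound 1 to compound 3 (beyond the scatter), and this step lies beyond the scatter. Within the data shown here, it is the first step that can be read in this set, and it shows that the substituent on this aromatic carbon, para to a large group, is not silent: with the rest of compound 1 unchanged, this one exchange alone shifts the growth inhibition. No measurement at hand accounts for the difference between cyano and nitro at this place.

Still open, as far as these compounds go, is how far the number would move with another group at this position, such as an amine or a carboxylic acid. From the compounds shown here alone, it is also open whether cyano in place of nitro would give a step of similar size if the ethyl ester elsewhere on compound 3 were replaced by an amide.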